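Hydrazone series: five-membered heteroaryl in place of alkyl chain

The source may report more compounds than this note shows. Statements on the series, on what has been measured and on what is new or still open speak of the compounds shown alone.

Compound 1 `CC(=O)Nc1ccc(/C=N/Nc2nc(N)c3ncn([C@@H]4O[C@H](CO)[C@@H](O)[C@H]4O)c3n2)cc1`: in an assay on CHO-K1 cells for displacement of a labelled ligand from adenosine receptor A1 (Homo sapiens), read by scintillation counting, with a stated time of 60 min (a lower number here means a stronger inhibitor, a higher number a weaker inhibitor), compound 1 gives > 10000 nM, a limit of the assay.
Compound 2 `Nc1nc(N/N=C/c2cncs2)nc2c1ncn2[C@@H]1O[C@H](CO)[C@@H](O)[C@H]1O`: in this assay compound 2 gives 22 nM.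
Compound 3 `CSCC/C=N/Nc1nc(N)c2ncn([C@@H]3O[C@H](CO)[C@@H](O)[C@H]3O)c2n1`: in this assay compound 3 gives > 10000 nM, a limit of the assay.

Compound 3 stands at the limit of this assay, as does compound 1 per (the limit of > 10000 nM in this assay, at which 2 of the 3 values shown sit); only compound 2 yields a number. The change from compound 3 to compound 4 `Nc1nc(N/N=C/c2ccc[nH]2)nc2c1ncn2[C@@H]1O[C@H](CO)[C@@H](O)[C@H]1O` is 1H-pyrrol-2-yl in place of 2-(methylsulfanyl)ethyl on a carbon with a double bond to nitrogen. The step of an at least 450-fold higher number from compound 2 to compound 3 (2.65 log units; beyond the scatter) bears on it most directly, exchanging a five-membered aromatic ring for the same chain; an at least 450-fold lower number from compound 1 to compound 2 (2.65 log units; beyond the scatter) sets the thiazolyl ring against 4-acetamidophenyl; a step that the two limits leave unreadable from compound 1 to compound 3 stays unreadable. Reversing the first of these, a large step to a lower number is expected for compound 4, an at least 160-fold lower number from compound 3 to compound 4 (2.22 log units; beyond the scatter). Compound 4 is estimated at 60 nM, between 10 nM and 600 nM.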

Compound 4, inhibition constant: 8 nM
Compound 4: middle estimate off by 7.5-fold (0.88 log units), on the high side, outside the stated range (below it).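

A second five-membered aromatic ring on the carbon with a double bond to nitrogen keeps the strong binding seen with compound 2, and the two rings can be told apart: a 2.8-fold lower number from compound 2 to compound 4 (0.44 log units; beyond the scatter). Against the open chain the step is an at least 1200-fold lower number from compound 3 to compound 4 (3.09 log units; beyond the scatter), and against the substituted phenyl it is an at least 1200-fold lower number from compound 1 to compound 4 (3.09 log units; beyond the scatter); both are bounds only, since compound 3 and compound 1 sit at a limit: the limit of > 10000 nM in this assay, at which 2 of the 4 values shown sit.

Open, going by these compounds, is how furan-2-yl or 1-methylpyrrol-2-yl would fare here. Plain phenyl would show whether the ring or its acetamido group separates compound 1 from compound 4.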